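Cyclohexyl Swap on a Non-Toxic Core

The source may report more compounds than this note shows. Statements on the series, on what has been measured and on what is new or still open speak of the compounds shown alone.

Compound 1, `COc1ccccc1Cn1ccc2nc(-c3ccccc3)nc-2c1`: > 100000 nM
Compound 2, `Clc1ccc(Cn2ccc3nc(-c4ccccc4)nc-3c2)cc1`: > 100000 nM

Both numbers come from an ADME assay on MDBK cells (Bos taurus) for cytotoxicity; on this read-out higher numbers stand for lower toxicity in this test and lower numbers for higher toxicity in this test. For compound 1 the value > 100000 nM is a limit of the assay, not a measured number. For compound 2 the value > 100000 nM is likewise a limit. The step that the two limits leave unreadable from compound 1 to compound 2 therefore cannot be sized; what the two results share is the limit of > 100000 nM in this assay, at which 2 of the 2 values shown sit, and compound 2 stands at that limit, with no number of its own on this read-out.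

Compound 3, `c1ccc(-c2nc3ccn(CC4CCCCC4)cc-3n2)cc1`, differs from compound 2 by cyclohexyl in place of 4-chlorophenyl on a saturated chain carbon bound to an aromatic nitrogen. For the measured compounds named here, the single measured step, from compound 1 to compound 2, changed the group at the same place, but its size is unreadable, so it gives no direction for the new change. Compound 3 is expected to give 150000 nM, in the range 50000 nM to 400000 nM, and most probably the assay will again report only a limit. The expected step that the limit leaves unreadable from compound 2 to compound 3 is thus none beyond the scatter.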

Compound 3, half-maximal cytotoxic concentration: > 100000 nM
Compound 3 ended at the assay's limit (the forecaster's own chance of this, stated with the estimate: 75%); the middle value lies beyond the limit too.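

Compound 3 adds no readable step: in this assay, its result is a limit, as are those of compound 1 and compound 2, and the steps among them cannot be sized. All three stop at the same point: the limit of > 100000 nM in this assay, at which 3 of the 3 values shown sit.

Left open is whether the 2-methoxyphenyl, 4-chlorophenyl and cyclohexyl compounds differ at all in toxicity to these cells.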